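This account rests on a few compounds, and the source may have more. Where it says the series, first, only, none or still open, it means among the compounds named here.

Three compounds share one core and carry an amino acid ester on a flexible chain. Compound 2 `N[C@H](C(=O)OCCCOC1(c2ccc(Cl)cc2)c2ccccc2C(=O)N1Cc1ccccc1)c1ccccc1` gives 43000 nM in a functional assay on HCT-116 cells (Homo sapiens) for inhibition, read by fluorescence, with a stated time of 48 h (on this read-out lower numbers stand for stronger inhibition of growth and higher numbers for weaker inhibition of growth), the lowest of the three numbers, yet every gap to the others is within the usual scatter, so no order among them can be read. Compound 3 `CC(C)(COC(=O)[C@@H](N)c1ccccc1)COC1(c2ccc(Cl)cc2)c2ccccc2C(=O)N1Cc1ccccc1` gives 44000 nM in this assay, and compound 1 `CC(C)[C@H](N)C(=O)OCCCOC1(c2ccc(Cl)cc2)c2ccccc2C(=O)N1Cc1ccc(Cl)cc1` gives 60000 nM; compound 1 differs from compound 2 in two places at once, so its number alone says little about either change.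

Compound 4 `N[C@H](C(=O)OCCCOC1(c2ccc(Cl)cc2)c2ccccc2C(=O)N1Cc1ccc(Cl)cc1)c1ccccc1` has not been measured. It differs from compound 2 by chloro in place of hydrogen on an aromatic carbon, so that the benzyl becomes a 4-chlorobenzyl. Within the data shown here, no single step of this kind is available among the measured compounds; the only hint is compound 1, which already carries the 4-chlorobenzyl and gives 60000 nM. The expected step from compound 2 to compound 4 is a 1.2-fold higher number from compound 2 to compound 4 (0.07 log units; within the scatter), none beyond the scatter. Compound 4 is therefore estimated at 50000 nM, with a likely range from 25000 nM to 100000 nM.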

Compound 4, concentration for 50% growth inhibition: 45000 nM
Compound 4: the middle estimate sits 1.1-fold (0.05 log units) above what was measured; low and high end bracket the measured number.
By their numbers in this assay, from the lowest: compounds 2, 3, 4 and 1 (each within the scatter of the next).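

The step of chloro in place of hydrogen on the aromatic carbon reads a 1.0-fold higher number from compound 2 to compound 4 (0.02 log units; within the scatter) in this assay, so this single change, from benzyl to 4-chlorobenzyl, leaves no readable mark on growth inhibition. The second step, phenyl in place of isopropyl on the chain carbon bound to the amine nitrogen and the carbonyl carbon, reads a 1.3-fold lower number from compound 1 to compound 4 (0.12 log units; within the scatter) and is equally unreadable, which separates the two changes that compound 1 carried at once. Nothing measured here offers a reason for either result.

Going by these compounds, whether a methoxy group or a nitrile at this place, or chloro on another carbon of the ring, would give a step beyond the scatter remains open. So does the effect of a carboxylic acid in place of the ester, or of a longer chain.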